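Chain length at the carbamate end of the shared core

The source may report more compounds than this note shows. Statements on the series, on what has been measured and on what is new or still open speak of the compounds shown alone.

Measured compounds:
Compound 1 `CCN(CC)C(=O)NC(=O)Nc1c(C(C)C)cccc1C(C)C`; in an assay on microsomes from intestine for inhibition of acyl-CoA:cholesterol acyltransferase (Oryctolagus cuniculus) (on this read-out lower numbers stand for stronger inhibition and higher numbers for weaker inhibition), compound 1 reaches only the assay limit of > 5000 nM.
Compound 2 `CCCCN(CCCC)C(=O)NC(=O)Nc1c(C(C)C)cccc1C(C)C`; in this assay compound 2 gives 250 nM.
Compound 3 `CCCCCC(C)OC(=O)NC(=O)Nc1c(C(C)C)cccc1C(C)C`; in this assay compound 3 gives 1060 nM.

Compound 3 carries the highest of the two numbers in this assay; the nearest measured neighbour is compound 2, reached by a 4.2-fold higher number from compound 2 to compound 3 (0.63 log units; beyond the scatter). The value of compound 1 is a limit, not a number, so its distance to compound 3 is known only as an at least 4.7-fold lower number from compound 1 to compound 3 (0.67 log units; beyond the scatter).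

Compound 4 `CCCCCCCCCCCCCCC(C)OC(=O)NC(=O)Nc1c(C(C)C)cccc1C(C)C` differs from compound 3 in one place: nonyl in place of hydrogen on a saturated chain carbon, six bonds along the chain from an oxygen next to a carbonyl group. For the measured compounds named here, no measured pair carries this exact change. Going by the values given here, the only step that lengthens saturated chains is an at least 20-fold lower number from compound 1 to compound 2 (1.30 log units; beyond the scatter), a large fall in the number on the amide side of the carbonyl, with the limit of > 5000 nM in this assay, at which 1 of the 3 values shown sits, at its start. Whether a longer chain on the carbamate side acts the same is not shown; the change from compound 3 to compound 4 is larger than that from compound 1 to compound 2, and the measured pairs give no check on such a long chain.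

On this basis a lower number than for compound 3 is expected for compound 4, by about a 3.0-fold lower number from compound 3 to compound 4 (0.48 log units; beyond the scatter). For compound 4 the estimate in this assay is 350 nM, with a likely range from 100 nM to 1500 nM.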

Compound 4, half-maximal inhibitory concentration: 6800 nM
Beside the measured number, compound 4's estimate is 19-fold (1.29 log units) below it; measured number outside the range, above it.
By their numbers in this assay, from the lowest: compound 2; then compound 3; then compound 4.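

On the carbamate side, nonyl in place of hydrogen on a saturated chain carbon, six bonds along the chain from an oxygen next to a carbonyl group, gives a 6.4-fold higher number from compound 3 to compound 4 (0.81 log units; beyond the scatter) in this assay, so this long extension weakens inhibition at this position. The direction is opposite to that of the chain lengthening on the amide side, an at least 20-fold lower number from compound 1 to compound 2 (1.30 log units; beyond the scatter), and the shown compounds therefore give no single chain-length rule for both sides of the carbonyl. Compound 1, at the start of that amide-side step, stands at a limit and not at a number: the limit of > 5000 nM in this assay, at which 1 of the 4 values shown sits.

Going by these compounds, what remains open is the course of the activity between the chain of compound 3 and the chain of compound 4, since a 1-methyloctyl or 1-methyldecyl chain could show either a steady rise in the number or a lower number before the rise. Also open, on these data alone, are a shorter 1-methylpropyl chain, an unbranched hexyl chain, and whether a terminal amine or carboxylic acid on the long chain of compound 4 would change the result.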